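Methoxy Added to a Chlorophenyl Piperazine Amide

The compounds below may be only part of what the source reports. "The series", "measured", "known", "first", "only" and "open" are said of these compounds alone.

Measured so far in an assay on HEK293 cells for binding affinity to D(4) dopamine receptor (Homo sapiens), read by radioligand binding; a lower number here means a stronger inhibitor, a higher number a weaker inhibitor:
compound 1 `CC(C)(C)C(=O)NCCCCN1CCN(c2ccc(Cl)cc2)CC1`: 12.6 nM
compound 2 `COc1ccc(N2CCN(CCCCNC(=O)C(C)(C)C)CC2)cc1`: 316 nM
compound 3 `CC(C)(C)C(=O)NCCCCN1CCN(c2ccccc2)CC1`: 316 nM

Compound 1 is the strongest of the three, and its core differs from that of compound 3 by chloro in place of hydrogen on an aromatic carbon. The same kind of change now under study has already been made once: from compound 3 to compound 2 the difference is methoxy in place of hydrogen on an aromatic carbon, and in this assay it gave no change at the digits printed from compound 3 to compound 2 (within the scatter). Compound 4 `COc1cc(Cl)ccc1N1CCN(CCCCNC(=O)C(C)(C)C)CC1` carries the change (methoxy in place of hydrogen on an aromatic carbon), but the surroundings differ: here the methoxy sits ortho to a large group and meta to a chloro group, whereas in compound 2 it sits para to a large group. Resting on the flat step seen from compound 3 to compound 2, the step from compound 1 to compound 4 is expected to be a 1.6-fold higher number from compound 1 to compound 4 (0.20 log units; within the scatter). Compound 4 is therefore estimated at 20 nM, between 5 nM and 80 nM.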

Compound 4, inhibition constant: 15.9 nM
The estimate for compound 4 lay 1.3-fold (0.10 log units) above the measured number; the range from low to high includes it.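

In this assay, methoxy in place of hydrogen on an aromatic carbon gave a 1.3-fold higher number from compound 1 to compound 4 (0.10 log units; within the scatter) on the core of compound 1, and this step matches the earlier one: the same change on two cores in this assay, no change at the digits printed (within the scatter) from compound 3 to compound 2 and a 1.3-fold higher number (0.10 log units; within the scatter) from compound 1 to compound 4, 1.3-fold (0.10 log units) apart, within the scatter of two such steps. The change thus carried across these two cores with no step beyond the scatter, although in compound 4 the methoxy sits ortho to a large group and meta to a chloro group. Two pairs do not show that the change would stay flat on other cores or at other places on the ring.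

The compounds shown leave open whether an ethoxy or a hydroxy group in the same place would behave as methoxy does. Also open, going by these compounds, is whether a longer chain before the amide would alter the result.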